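A few compounds are considered here, and "the series" means these few. Any claim that something is new, unique, unknown or untested is made for them only; others in the source may bear on it.

In an ADME assay on HEK293 cells (Homo sapiens) for cytotoxicity, read by resazurin assay, with a stated time of 72 h (a higher number here means that more compound is tolerated, a lower number that less compound is tolerated), compound 3 `O=C(O)c1ccc(COCc2cccc3nc(C(=O)NCc4ccccc4)[nH]c(=O)c23)cc1` gives > 20000 nM, which is a limit and not a number. Compound 1 `CCc1cccc(CNC(=O)c2nc3cccc(COCc4ccc(C(=O)O)cc4)c3c(=O)[nH]2)c1` gives > 40000 nM, also a limit. Compound 2 `COc1cccc(CNC(=O)c2nc3cccc(COCc4ccc(C(=O)O)cc4)c3c(=O)[nH]2)c1` gives > 20000 nM, again a limit. Compound 4 `CCc1ccc(CNC(=O)c2nc3cccc(COCc4ccc(C(=O)O)cc4)c3c(=O)[nH]2)cc1` puts ethyl in place of hydrogen on an aromatic carbon, para to a large group: ethyl in place of hydrogen on an aromatic carbon. The closest measured change, hydrogen in place of ethyl, is a step that the two limits leave unreadable from compound 1 to compound 3, so it offers no size to carry over. The other two, a step that the two limits leave unreadable from compound 1 to compound 2 and a step that the two limits leave unreadable from compound 2 to compound 3, are just as unreadable. Compound 1 carries an ethyl and still reads > 40000 nM, a limit, so no change beyond the scatter is expected in this assay. The expected step is a step that the limit leaves unreadable from compound 3 to compound 4. Compound 4 is estimated at 30000 nM, with an expected range from 15000 nM to 60000 nM.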

Compound 4, half-maximal cytotoxic concentration: > 20000 nM
Compound 4 was reported as a limit; the forecaster's own chance of this, stated with the estimate: 85%; the middle value lies beyond the limit too.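

Compound 4 gives only a limit, as do compounds 1, 2 and 3, so no step among these four compounds can be read: the limit of > 20000 nM in this assay, at which 3 of the 4 values shown sit.

In this assay, on these data alone, the concentration at which any of these four compounds harms the cells stays open.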